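Aryl replacement at the saturated ring carbon

The source may report more compounds than this note shows. Statements on the series, on what has been measured and on what is new or still open speak of the compounds shown alone.

Measured so far:
compound 1 `COc1cccc(C(F)(F)F)c1C(=O)NC1(c2ccccc2)CCCN(C)C1`: 1500 nM
compound 2 `COc1cc(C(F)(F)F)cc(SC)c1C(=O)NC1(c2ccc(Cl)cc2)CCCN(C)C1`: 28 nM

In an assay on cells for inhibition of sodium- and chloride-dependent glycine transporter 1 (Homo sapiens) (a lower number here means that less compound is needed, a higher number that more compound is needed for the effect), compound 2 gives the lowest number of the two, and compound 1 stands well above it, beyond the scatter. Compound 3 `COc1cc(C(F)(F)F)cc(SC)c1C(=O)NC1(c2cnccn2)CCCN(C)C1` carries the change (pyrazin-2-yl in place of 4-chlorophenyl on a saturated ring carbon). Among the measured compounds shown here, no step between measured compounds covers this change, and what compound 1 shows concerns other positions of the core. For compound 3 the step of a 4.3-fold higher number from compound 2 to compound 3 (0.63 log units; beyond the scatter) is expected to run upward, beyond the scatter but by less than the gap separating compound 1 from compound 2. For compound 3 the estimate is 120 nM with a range from 30 nM to 500 nM in this assay.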

Compound 3, half-maximal effective concentration: 1670 nM
Beside the measured number, compound 3's estimate is 14-fold (1.14 log units) below it; measured number outside the range, above it.
By their numbers in this assay, from the lowest: compound 2; then compounds 1 and 3 (each within the scatter of the next).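

In this assay, pyrazin-2-yl in place of 4-chlorophenyl on the saturated ring carbon gives a 60-fold higher number from compound 2 to compound 3 (1.78 log units; beyond the scatter), a large step. Among the compounds shown here, this is the first change confined to one place, and it shows that the number depends strongly on the aromatic ring at this position. Nothing available explains the size of this step.

From the compounds shown here alone, it remains open whether the step follows from losing the chlorine or from the two ring nitrogens. Pyridin-2-yl, with one ring nitrogen, or 4-chloropyridin-2-yl at this position on the core of compound 2 would separate the two.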